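The source may report more compounds than this note shows. Statements on the series, on what has been measured and on what is new or still open speak of the compounds shown alone.

In a functional assay on A549 cells (Homo sapiens) for cytotoxicity, read by MTT assay, with a stated time of 68 h (on this read-out higher numbers stand for weaker inhibition and lower numbers for stronger inhibition), compound 2 (`O=C(Nc1cccc(-c2ccc(F)cc2)c1)C(Cl)Cl`) gives 7840 nM and sits within the scatter of compound 1 (`Cc1ccc(-c2cccc(NC(=O)C(Cl)Cl)c2)cc1`), which gives 8300 nM in this test. Compound 3 (`O=C(Nc1cc(-c2ccc(OC3CCCCO3)cc2)cc(-c2ccc(OC3CCCCO3)cc2)c1)C(Cl)Cl`) gives 2750 nM and lies lower than compound 2, beyond the scatter. Compound 4 (`COC(=O)c1ccc(-c2cccc(NC(=O)C(Cl)Cl)c2)cc1`) departs from compound 2 by one change: methoxycarbonyl in place of fluoro on an aromatic carbon. Within the data shown here, the only measured step at this carbon is a 1.1-fold lower number from compound 1 to compound 2 (0.02 log units; within the scatter) (fluoro in place of methyl) and it stayed within the scatter. Among the measured compounds shown here, no measured compound carries methoxycarbonyl, so the evidence is thin, and no step beyond the scatter is expected in this assay here. The estimated step is a 1.0-fold lower number from compound 2 to compound 4 (0.02 log units; within the scatter) and no more than that. Compound 4 is expected near 7500 nM (estimated range 3500 nM to 15000 nM).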

Compound 4, half-maximal inhibitory concentration: > 50000 nM
Compound 4 was reported as a limit; the forecaster's own chance of this, stated with the estimate: 5%; middle value at least 6.6-fold (0.82 log units) away from the limit.
By their numbers in this assay, from the lowest: compound 3; then compounds 2 and 1 (each within the scatter of the next). At a limit, above all of these: compound 4.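

In this assay, the aromatic carbon para to a large group no longer looks indifferent to its substituent: fluoro and methyl stayed within the scatter of each other, but methoxycarbonyl gives an at least 6.3-fold higher number from compound 2 to compound 4 (0.80 log units; beyond the scatter) and an at least 6.0-fold higher number from compound 1 to compound 4 (0.77 log units; beyond the scatter). Among these compounds, these are the first steps beyond the scatter at this carbon, and they show that a change here can weaken the read-out. The value of compound 4 is a limit and not a number: the limit of > 50000 nM in this assay, at which 1 of the 4 values shown sits.

On these data alone, how far compound 4 lies past that limit stays open. The compounds shown also do not tell whether a carboxylic acid or an amine on this carbon would behave like methoxycarbonyl or like fluoro and methyl.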